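Acetylated sugar analogues: acetamido replaced by acetoxy

The source may report more compounds than this note shows. Statements on the series, on what has been measured and on what is new or still open speak of the compounds shown alone.

Measured so far:
compound 1 `S=c1nc(-c2cc3ccccc3[nH]2)[nH][nH]1`: 15.9 ug/mL in a functional assay on HepG2 cells (Homo sapiens) for antiproliferative activity, read by sulforhodamine B assay, with a stated time of 48 h; a lower number here means a stronger inhibitor, a higher number a weaker inhibitor
compound 2 `CC(=O)N[C@@H]1[C@@H](OC(C)=O)[C@H](OC(C)=O)[C@@H](COC(C)=O)O[C@H]1n1nc(SCc2ccccc2)nc1-c1cc2ccccc2[nH]1`: in this assay compound 2 gives 16.6 ug/mL
compound 3 `C=CCn1nc(-c2cc3ccccc3[nH]2)nc1SCc1ccccc1`: in this assay compound 3 gives 15.9 ug/mL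

Three compounds share the same core, carrying either nothing, an acetylated amino-sugar with a benzylthio group, or an allyl group with a benzylthio group. In this assay all three numbers sit close together. Compound 2 has the highest of the three numbers, but its gap to compound 1 and its gap to compound 3 both fall within the scatter, so no order among them can be read from these values. Nothing in the three measured compounds points to the substituent on the core mattering for this read-out.

Compound 4 `CC(=O)OC[C@H]1O[C@@H](n2nc(SCc3ccccc3)nc2-c2cc3ccccc3[nH]2)[C@H](OC(C)=O)[C@@H](OC(C)=O)[C@@H]1OC(C)=O` is the next compound. Relative to compound 2 the change is acetoxy in place of acetamido on a saturated ring carbon of the sugar ring. Going by the values given here, no measured pair shows such a change, so there is no step to lean on. Given that compound 2 at 16.6 ug/mL and compound 1 at 15.9 ug/mL differ only within the scatter, the expectation is a step from compound 2 to compound 4 of about a 1.0-fold lower number from compound 2 to compound 4 (0.02 log units; within the scatter), that is, none beyond the scatter. Compound 4 is therefore estimated at 16 ug/mL, within 8 ug/mL to 32 ug/mL.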

Compound 4, half-maximal inhibitory concentration: 16.1 ug/mL
Compound 4: middle estimate off by 1.0-fold (0.00 log units), on the low side; the measured number falls inside the stated range.
By their numbers in this assay, from the lowest: compounds 1, 3, 4 and 2 (each within the scatter of the next).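

In this assay, going by these compounds alone, acetoxy in place of acetamido on a saturated ring carbon gives a 1.0-fold lower number from compound 2 to compound 4 (0.01 log units; within the scatter) and is the first change that can be read at a single place, here on the six-membered non-aromatic ring with 1 oxygen. The earlier compounds shown here differ from one another in more than one place, so their closeness could not speak for this position; this pair shows that, with everything else held constant, the exchange leaves the number within the scatter, even though the amide hydrogen is absent from compound 4. No available measurement bears on why this step is so small.

Going by these compounds, it remains open whether an amine, a hydroxyl or a carboxylic acid on this ring carbon, or a chain longer than acetamido, would give a step beyond the scatter in this assay. On these data alone, whether the same holds with hydroxyl groups in place of the remaining acetoxy groups and the acetoxymethyl group on this ring also remains open.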